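Butyl to 3-methoxypropyl: will the limit hold?

A few compounds are considered here, and "the series" means these few. Any claim that something is new, unique, unknown or untested is made for them only; others in the source may bear on it.

Compound 2 (`CCCCOc1ccc(C(O)C2OC(=O)c3c(OC)cc(OC)cc32)cc1`) carries butyl in place of hydrogen on an oxygen on an aromatic ring of compound 1 (`COc1cc(OC)c2c(c1)C(C(O)c1ccc(O)cc1)OC2=O`). In an ADME assay on RAW264.7 cells (Mus musculus) for cytotoxicity, read by MTT assay, with a stated time of 24 h, in the presence of a further agent that is not named here (a higher number here means a weaker inhibitor, a lower number a stronger inhibitor), compound 1 gives > 40000 nM as a limit of the assay, not a number. In this assay compound 2 gives > 40000 nM as a limit too. Compound 2 therefore has no exact place on the scale, and the data so far amount to the limit of > 40000 nM in this assay, at which 2 of the 2 values shown sit, and nothing more.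

Compound 3 (`COCCCOc1ccc(C(O)C2OC(=O)c3c(OC)cc(OC)cc32)cc1`) differs from compound 2 in one place: methoxy in place of methyl on a saturated chain carbon, three bonds along the chain from an oxygen on an aromatic ring turns butyl into 3-methoxypropyl. Going by the values given here, the only measured step that bears on this is a step that the two limits leave unreadable from compound 1 to compound 2 and its size cannot be read. Among the compounds with values here, with the limit of > 40000 nM in this assay, at which 2 of the 2 values shown sit, as the only guide, no step beyond the usual scatter is expected in this assay and compound 3 will probably report only a limit again. The expected step is a step that the limit leaves unreadable from compound 2 to compound 3 by this estimate. For compound 3 the estimated value is 50000 nM with an expected range from 25000 nM to 100000 nM on this estimate.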

Compound 3, half-maximal inhibitory concentration: > 40000 nM
Compound 3 ended at the assay's limit; the forecaster's own chance of this, stated with the estimate: 85%; the middle value does not contradict the limit.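

Going by these compounds alone, compound 3 also ends at a limit of the assay rather than a number, so no step among compound 1, compound 2 and compound 3 can be read: the limit of > 40000 nM in this assay, at which 3 of the 3 values shown sit. Left open is whether any change to the shared core would give a readable value in this assay at all, and where each of these three compounds truly lies.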